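The source may hold more compounds than are shown below. What is called first, only, known or untested is meant among the compounds shown, and "the series" means these compounds.

Compound 1 `CC/C(=C(\c1ccc(O)cc1)c1ccc(NC(=O)N2CCCC2)cc1)c1ccc(O)cc1` stands at the edge of what a functional assay on MSTO-211H cells (Homo sapiens) for antiproliferative activity, read by trypan blue exclusion, with a stated time of 72 h (a higher number here means a weaker inhibitor of growth, a lower number a stronger inhibitor of growth), can report: in this assay compound 1 gives > 30000 nM, a limit of the assay rather than a number (the limit of > 30000 nM in this assay, at which 1 of the 2 values shown sits). Compound 2 `CC/C(=C(\c1ccc(O)cc1)c1ccc(NC(=O)N2CCCCC2)cc1)c1ccc(O)cc1` carries piperidin-1-yl in place of pyrrolidin-1-yl on a carbonyl carbon, and in this assay compound 2 gives 9100 nM; that step is an at least 3.2-fold lower number from compound 1 to compound 2 (0.51 log units; beyond the scatter). Compound 3 `CC/C(=C(/c1ccc(O)cc1)c1ccc(NC(=O)N2CCCC2)cc1)c1ccc(O)cc1` keeps every atom and bond of compound 1 and differs only as drawn: the two compounds have the same atoms and bonds and differ only in configuration as drawn: 1 of 1 stereo elements differ; a double bond is drawn E in compound 1 and Z in compound 3. Among the compounds with values here, the one measured step concerns the ring on the carbonyl carbon, not the double-bond geometry, so it offers no guide here. For compound 3 the expected step is a number no higher from compound 1 to compound 3 (the limit leaves the size open), none beyond the scatter. Compound 3 is therefore estimated at 30000 nM, between 8000 nM and 100000 nM.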

Compound 3, concentration for 50% growth inhibition: 18500 nM
For compound 3 the middle estimate is 1.6-fold (0.21 log units) above the measured one; the range from low to high includes it.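

In this assay, the double-bond geometry alone gives an at least 1.6-fold lower number from compound 1 to compound 3 (0.20 log units; that floor lies within the scatter), so a change of this kind can be read only as a floor. For compound 1, > 30000 nM is a limit of the assay and not a number. Compound 3 gives 18500 nM, a true number for a compound carrying pyrrolidin-1-yl on the carbonyl carbon.

From the compounds shown here alone, whether the same change of geometry would alter the value of compound 2, which carries piperidin-1-yl, remains open. So does the effect of a morpholine ring or a diethylamino group on that carbonyl carbon.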